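Clearance step from compound 3 to compound 4

This account rests on a few compounds, and the source may have more. Where it says the series, first, only, none or still open, it means among the compounds named here.

Of the compounds shown here, three have been read in an in vivo ADME assay on the whole organism (plasma, strain Sprague-Dawley) for pharmacokinetics, with Rattus norvegicus as the target, read by LC-MS; on this read-out lower numbers stand for slow clearance and higher numbers for fast clearance. Compound 1 (`CC(C)(C)c1cc(NC(=O)Nc2ccc(NC(=O)c3ccc(OC4CCN(C(C)(C)C)CC4)cn3)cc2)no1`) gives 15 mL/min/kg, compound 2 (`CC(C)(C)c1cc(NC(=O)Nc2ccc(NC(=O)c3ccc(OC4CCNCC4)cn3)cc2)no1`) gives 22.1 mL/min/kg, and compound 3 (`CC1(C)CC(Oc2ccc(C(=O)Nc3ccc(NC(=O)Nc4cc(C(C)(C)C)on4)cc3)nc2)CC(C)(C)N1`) gives 11 mL/min/kg. Compound 3 is not separated from the other two, as the steps show: a 1.4-fold lower number from compound 1 to compound 3 (0.13 log units; within the scatter) and a 2.0-fold lower number from compound 2 to compound 3 (0.30 log units; within the scatter).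

The unmeasured compound 4 (`CCN1CCC(Cc2ccc(C(=O)Nc3ccc(NC(=O)Nc4cc(C(C)(C)C)on4)cc3)nc2)CC1`) differs from compound 3 in one place: (1-ethylpiperidin-4-yl)methyl in place of (2,2,6,6-tetramethylpiperidin-4-yl)oxy on an aromatic carbon. The group sits on an aromatic carbon of a six-membered aromatic ring with 1 nitrogen, para to a large group.

The remaining measured step in this part of the structure is a 1.5-fold higher number from compound 1 to compound 2 (0.17 log units; within the scatter). Together with the two above, it shows that exchanges among the groups on the oxygen have stayed within the scatter. Among the compounds with values here, none of the measured compounds lacks that oxygen, so the data do not cover that part of the change directly. The expectation therefore rests on weak evidence, and a wide range is kept. No shift beyond the scatter is expected, and the estimated step is a 1.5-fold higher number from compound 3 to compound 4 (0.19 log units; within the scatter). Compound 4 is estimated at 17 mL/min/kg, with an expected range from 8 mL/min/kg to 36 mL/min/kg.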

Compound 4, clearance: 24 mL/min/kg
Beside the measured number, compound 4's estimate is 1.4-fold (0.15 log units) below it; measured number inside the range.
By their numbers in this assay, from the lowest: compounds 3, 1, 2 and 4 (each within the scatter of the next, the first and the last beyond it).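

In this assay, within the data shown here, (1-ethylpiperidin-4-yl)methyl in place of (2,2,6,6-tetramethylpiperidin-4-yl)oxy gives the only step that lies beyond the scatter, a 2.2-fold higher number from compound 3 to compound 4 (0.34 log units; beyond the scatter), and it is a modest one, whereas the exchanges among the groups on the oxygen all stayed within it. The separation holds only against compound 3: the corresponding changes from the other two ethers remain within the scatter, at a 1.1-fold higher number from compound 2 to compound 4 (0.04 log units; within the scatter) and a 1.6-fold higher number from compound 1 to compound 4 (0.20 log units; within the scatter), so loss of the oxygen does not give a clear shift across all the ethers shown. No measurement is available that accounts for the step from compound 3 to compound 4.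

The step changes the linking atom and the substitution of the piperidine ring at once, leaving open how much of it belongs to each part. A (1-ethylpiperidin-4-yl)oxy group or a (2,2,6,6-tetramethylpiperidin-4-yl)methyl group on this aromatic carbon would separate the two parts, and a longer chain between the rings would test whether the length of the link matters at this position.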